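Clearance notes: from compound 3 to compound 4

The source may hold more compounds than are shown below. What is called first, only, known or untested is meant among the compounds shown, and "the series" means these compounds.

In an in vivo ADME assay on the whole organism (strain 129/SvEvBrd x C57BL/6) for pharmacokinetics, with Mus musculus as the target, at a dose of 1 mg/kg by the intravenous route (a lower number here means slower removal, a higher number faster removal of the compound), compound 1 `CC(=O)c1cccc([C@@H](O)[C@H](O)[C@H](O)CO)n1` gives 14 mL/min/kg and compound 2 `CC(=O)N/N=C(\C)c1nc([C@@H](O)[C@H](O)[C@H](O)CO)c[nH]1` gives 8.9 mL/min/kg while compound 3 `OC[C@@H](O)[C@@H](O)[C@H](O)c1c[nH]c(-c2cscn2)n1` gives 12.7 mL/min/kg and these three values all lie within the usual scatter of one another. Compound 3 therefore stands level with both other compounds, and no order can be read among them. Compound 4 `Cn1cnc(-c2nc([C@@H](O)[C@H](O)[C@H](O)CO)c[nH]2)c1` carries 1-methyl-1H-imidazol-4-yl in place of 1,3-thiazol-4-yl on an aromatic carbon and remains unmeasured. Among the measured compounds shown here, no measured pair differs in one place only, so direct evidence on this change is lacking. The expected change a 1.2-fold lower number from compound 3 to compound 4 (0.06 log units; within the scatter) is no larger than the scatter, with no clear direction. Compound 4 is expected at 11 mL/min/kg with an estimated range from 5.5 mL/min/kg to 22 mL/min/kg in this series.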

Compound 4, clearance: 9.1 mL/min/kg
The estimate for compound 4 lay 1.2-fold (0.08 log units) above the measured number, and the stated range covers the measured number.
By their numbers in this assay, from the lowest: compounds 2, 4, 3 and 1 (each within the scatter of the next).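

In this assay the series now holds its first single-place step: on an aromatic carbon between two ring nitrogen atoms, 1-methyl-1H-imidazol-4-yl in place of 1,3-thiazol-4-yl gives a 1.4-fold lower number from compound 3 to compound 4 (0.14 log units; within the scatter) and so no readable change in clearance. At this position, the sulfur-containing ring can give way to a ring with two nitrogen atoms and one more heavy atom without leaving the scatter. Nothing available explains this result.

As far as these compounds go, whether a non-aromatic group here, such as an amine or a carboxylic acid, would also stay within the scatter remains open. The separate contribution of the methyl group on the ring nitrogen is also unresolved.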